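The source may report more compounds than this note shows. Statements on the series, on what has been measured and on what is new or still open speak of the compounds shown alone.

Measured compounds:
Compound 1, `COc1ccc(/C=C/c2cc(C)n[nH]2)cc1`: 8400 nM
Compound 2, `COc1ccc(/C=C/c2cc(C)n[nH]2)cc1OC`: 18500 nM
Compound 3, `Cc1cc(/C=C/c2ccc(O)cc2)on1`: 67200 nM

All three were tested in a functional assay on DU-145 cells (Homo sapiens) for cytotoxicity, read by MTT assay, with a stated time of 72 h; a higher number here means a weaker inhibitor, a lower number a stronger inhibitor. Compound 1 and compound 2 share one core and differ in a single place: methoxy in place of hydrogen on an aromatic carbon. This change made the number rise by a 2.2-fold higher number from compound 1 to compound 2 (0.34 log units; beyond the scatter).

Compound 3 stands on a different core, and the difference between the two cores is not broken down here. In this assay compound 3 gives 67200 nM, the highest number of the three, so that it reads as the weakest inhibitor of the group.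

Compound 4, `COc1cc(/C=C/c2cc(C)no2)ccc1O`, is not yet measured. It differs from compound 3 in one place: methoxy in place of hydrogen on an aromatic carbon. Among the compounds with values here, this is the same kind of change as the one from compound 1 to compound 2, but the surroundings of the place are not the same: in compound 4 the new group sits ortho to a hydroxy group, while in compound 2 it sits ortho to a methoxy group; in both cases it lies meta to a group of 8 heavy atoms.

For compound 4 a step of a 1.6-fold higher number from compound 3 to compound 4 (0.21 log units; within the scatter) is expected, resting on the modest rise seen from compound 1 to compound 2 (a 2.2-fold higher number from compound 1 to compound 2 (0.34 log units; beyond the scatter)) and on the already high number of compound 3, 67200 nM. The estimate for compound 4 in this assay is 110000 nM, within a range from 50000 nM to 250000 nM.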

Compound 4, half-maximal inhibitory concentration: 28900 nM
The estimate for compound 4 lay 3.8-fold (0.58 log units) above the measured number; measured number below the stated range.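

In this assay, methoxy in place of hydrogen on an aromatic carbon did not behave as one fixed step when carried from one core to the other: the same change on two cores in this assay, a 2.2-fold higher number (0.34 log units; beyond the scatter) from compound 1 to compound 2 and a 2.3-fold lower number (0.37 log units; beyond the scatter) from compound 3 to compound 4, 5.1-fold (0.71 log units) apart, beyond the scatter of two such steps The new step, a 2.3-fold lower number from compound 3 to compound 4 (0.37 log units; beyond the scatter), runs in the opposite direction to the earlier one, a 2.2-fold higher number from compound 1 to compound 2 (0.34 log units; beyond the scatter), so in this series the direction of the change on one core did not foretell its direction on the other. Within the data shown here, what this does not show is where the reversal comes from, since each core supplies only one pair and the two pairs differ both in the core and in the surroundings of the new group, which in compound 4 sits ortho to a hydroxy group, a setting that compound 2 does not share.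

The compounds shown leave open whether the reversal follows the core or the hydroxy group, a question that a hydroxy group in the same setting on the core of compound 1 would bear on directly. They also leave open how other groups at this place, such as an amine, a carboxylic acid or a longer ether chain, would move the number on either core.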